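The source may hold more compounds than are shown below. What is called first, only, known or untested is meant among the compounds shown, and "the series" means these compounds.

Measured so far:
- compound 1, `CCCC(=O)N1CC2CC(C1)N2`: 14 nM
- compound 2, `O=C([C@@H]1C[C@H]1F)N1CC2CC(C1)N2`: 1 nM

Compound 1 holds the highest number of the two in an assay on SH-EP1 cells for displacement of a labelled ligand from Neuronal acetylcholine receptor; alpha4/beta2 (Homo sapiens), read by scintillation counting; on this read-out higher numbers stand for weaker inhibition and lower numbers for stronger inhibition; its nearest neighbour is compound 2, which differs in one place and gives a 14-fold lower number from compound 1 to compound 2 (1.15 log units; beyond the scatter). The unmeasured compound 3, `C[C@@H]1C[C@H]1C(=O)N1CC2CC(C1)N2`, differs from compound 1 as follows: 2-methylcyclopropyl in place of propyl on a carbonyl carbon. Among the compounds with values here, the only step that bears on it is the one from compound 1 to compound 2, where a three-membered ring carrying a fluorine entered on the same carbonyl carbon; here the ring enters carrying a methyl instead. Whether methyl repeats what fluorine did is not shown by any measured pair, so the expected step is directed downwards but held short of the fluorine case. Compound 3 is therefore expected at 3 nM, range 1 nM to 12 nM, a step of a 4.7-fold lower number from compound 1 to compound 3 (0.67 log units; beyond the scatter) in this assay.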

Compound 3, inhibition constant: 1 nM
Estimate against measurement, compound 3: 3.0-fold (0.48 log units) above, within the range that was stated.
By their numbers in this assay, from the lowest: compounds 2 and 3 (each within the scatter of the next); then compound 1.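

In this assay, the lower number seen with the fluorinated ring does not depend on fluorine: 2-methylcyclopropyl in place of propyl on the carbonyl carbon gives the same large drop (a 14-fold lower number from compound 1 to compound 3 (1.15 log units; beyond the scatter)), and methyl in place of fluoro on the saturated ring carbon gives no readable shift (no change at the digits printed from compound 2 to compound 3 (within the scatter)). For these three compounds, this position tolerates either substituent on the three-membered ring, and both substituted rings stand apart from the open propyl chain. No evidence shown explains either step.

Open, as far as these compounds go, is whether an unsubstituted cyclopropyl group on the same carbonyl carbon would match these substituted rings, or whether the substituent contributes at all. Also open, from the compounds shown here alone, are the other stereoisomers of the ring and how a cyclobutyl ring, a longer chain or an amine on the ring would behave here.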